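From compound 2 to compound 3: cytotoxicity at the limit

The compounds below may be only part of what the source reports. "The series", "measured", "known", "first", "only" and "open" are said of these compounds alone.

Compound 1 `OC[C@H]1O[C@@H](n2cnc3c(COc4ccccc4)ncnc32)[C@H](O)[C@@H]1O`: > 100000 nM
Compound 2 `O=c1ccn(Cc2ncnc3c2ncn3[C@@H]2O[C@H](CO)[C@@H](O)[C@H]2O)cc1`: > 100000 nM

In a functional assay on Huh-7 cells (Homo sapiens) for cytotoxicity, read by MTT assay, with a stated time of 3 days (a higher number here means that more compound is tolerated, a lower number that less compound is tolerated), compound 2 gives > 100000 nM, which is a limit and not a number. Compound 1 gives > 100000 nM, which is also a limit. Compound 2 therefore has no exact position, and the data show only (the limit of > 100000 nM in this assay, at which 2 of the 2 values shown sit).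

Compound 3 `OC[C@H]1O[C@@H](n2cnc3c(COc4ccccn4)ncnc32)[C@H](O)[C@@H]1O` keeps the core of compound 2, but the group on a saturated chain carbon bound to an aromatic carbon changes. There, (pyridin-2-yl)oxy enters: a group of 7 heavy atoms (5 carbon, 1 nitrogen, 1 oxygen; one six-membered aromatic ring with 1 hetero atom) in place of a group of 7 heavy atoms (5 carbon, 1 nitrogen, 1 oxygen; one six-membered aromatic ring with 1 hetero atom), on a saturated chain carbon bound to an aromatic carbon.

Among the measured compounds shown here, the only measured step that bears on this change is a step that the two limits leave unreadable from compound 1 to compound 2. It offers no size to carry over, so the expectation rests on the two limits alone. No step beyond the usual scatter is expected in this assay, in either direction, and another limit is the likeliest result. The expected change is a number no higher from compound 2 to compound 3 (the limit leaves the size open). Compound 3 is estimated at 100000 nM, with an expected range of 40000 nM to 150000 nM.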

Compound 3, half-maximal cytotoxic concentration: > 250000 nM
Compound 3: no number, only a limit; the forecaster's own chance of this, stated with the estimate: 85%; at least 2.5-fold (0.39 log units) between middle value and limit.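

In this assay compound 3 gives > 250000 nM, which is a limit and not a number. Compound 1 and compound 2 also have only limits, so none of the steps among these three compounds can be read. The compounds shown leave open the concentration at which any of them harms these cells, and whether changing the group alters it.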